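Hydroxy kept, bromine lost: compound 3 to compound 4

A few compounds are considered here, and "the series" means these few. Any claim that something is new, unique, unknown or untested is made for them only; others in the source may bear on it.

In a functional assay on HepG2 cells (Homo sapiens) for cytotoxicity, read by MTT assay, with a stated time of 72 h (on this read-out higher numbers stand for weaker inhibition and lower numbers for stronger inhibition), compound 1 `O=C(N/N=C/c1cccc(Br)c1)Nc1cc2c(Nc3ccc(F)c(Cl)c3)ncnc2cc1O[C@H]1CCOC1` gives 32300 nM and compound 2 `COc1ccc(/C=N/NC(=O)Nc2cc3c(Nc4ccc(F)c(Cl)c4)ncnc3cc2O[C@H]2CCOC2)cc1` gives 28800 nM in the same range. Compound 3 `O=C(N/N=C/c1ccc(O)c(Br)c1)Nc1cc2c(Nc3ccc(F)c(Cl)c3)ncnc2cc1O[C@H]1CCOC1` stands lowest of the three (660 nM). Hydroxy in place of hydrogen on an aromatic carbon accounts for a 49-fold lower number from compound 1 to compound 3 (1.69 log units; beyond the scatter) and the other comparison shows a 44-fold lower number from compound 2 to compound 3 (1.64 log units; beyond the scatter) of similar size. Compound 4 `CCN(CC)c1ccc(/C=N/NC(=O)Nc2cc3c(Nc4ccc(F)c(Cl)c4)ncnc3cc2O[C@H]2CCOC2)c(O)c1` carries 4-(diethylamino)-2-hydroxyphenyl in place of 3-bromo-4-hydroxyphenyl on a carbon with a double bond to nitrogen. For the measured compounds named here, a hydroxy stays, but no measured compound carries diethylamino, and only one measured compound carries hydroxy. Part of the large step is expected to be lost, so the expected step is a 4.5-fold higher number from compound 3 to compound 4 (0.66 log units; beyond the scatter) in this assay towards a higher number. Compound 4 is estimated at 3000 nM (range 500 nM to 20000 nM).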

Compound 4, half-maximal inhibitory concentration: 15700 nM
Compound 4: middle estimate off by 5.2-fold (0.72 log units), on the low side; low and high end bracket the measured number.
By their numbers in this assay, from the lowest: compound 3; then compounds 4, 2 and 1 (each within the scatter of the next, the first and the last beyond it).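

A hydroxy on the ring does not by itself keep the low number in this assay: 4-(diethylamino)-2-hydroxyphenyl in place of 3-bromo-4-hydroxyphenyl gives a large loss (a 24-fold higher number from compound 3 to compound 4 (1.38 log units; beyond the scatter)). Set against the two groups without hydroxy, the new group gives little (a 1.8-fold lower number from compound 2 to compound 4 (0.26 log units; within the scatter); a 2.1-fold lower number from compound 1 to compound 4 (0.31 log units; beyond the scatter)), the first step within the scatter and the second modest. No evidence at hand accounts for this loss.

Open, from the compounds shown here alone, is whether the low number needs the bromine, the hydroxy or both together on the ring. Also open, going by these compounds, is how a ring carrying hydroxy with dimethylamino, or with a carboxylic acid, would read.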